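A few compounds are considered here, and "the series" means these few. Any claim that something is new, unique, unknown or untested is made for them only; others in the source may bear on it.

Notes on the series. Compound 1 `O=C(O)COCCCCC1=CCC[C@@H]1NS(=O)(=O)c1ccc(Cl)c(Cl)c1` and compound 2 `O=C(O)COCCCCC1=CCC[C@@H]1NS(=O)(=O)c1ccccc1[N+](=O)[O-]` share one core and differ only in the group on the sulfonyl sulfur; compound 3 `O=C(O)CCC/C=C\C[C@H]1[C@H](F)CC[C@@H]1NS(=O)(=O)c1ccccc1[N+](=O)[O-]` is built on a second core, and the difference between the two cores is not broken down here. In a functional assay on a cell-free system (plasma) for inhibition of thromboxane A2 receptor (Homo sapiens), read by turbidimetry (on this read-out lower numbers stand for stronger inhibition and higher numbers for weaker inhibition), compound 1 gives 1900 nM, compound 2 gives 1900 nM and compound 3 gives 1800 nM; all three numbers lie within the scatter of one another. The measured change 3,4-dichlorophenyl in place of 2-nitrophenyl on a sulfonyl sulfur produced no change at the digits printed from compound 2 to compound 1 (within the scatter). Compound 4 `O=C(O)CCC/C=C\C[C@H]1[C@H](F)CC[C@@H]1NS(=O)(=O)c1ccc(Cl)c(Cl)c1` carries the same change applied to the core of compound 3: 3,4-dichlorophenyl in place of 2-nitrophenyl on a sulfonyl sulfur. In both cases the place is described in the same words, a sulfonyl sulfur whose other neighbours are the sulfonamide nitrogen, so the change is taken as the same. The step from compound 3 to compound 4 is expected to be no change at the digits printed from compound 3 to compound 4 (within the scatter), set beside the earlier step because no change at the digits printed from compound 2 to compound 1 (within the scatter) showed no shift beyond the scatter. Compound 4 is therefore estimated at 1800 nM in this assay, with an expected range from 900 nM to 3600 nM.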

Compound 4, half-maximal inhibitory concentration: 630 nM
The estimate for compound 4 lay 2.9-fold (0.46 log units) above the measured number; measured number outside the range, below it.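

On the second core the change to 3,4-dichlorophenyl on a sulfonyl sulfur gives a 2.9-fold lower number from compound 3 to compound 4 (0.46 log units; beyond the scatter), whereas on the first core it gives no change at the digits printed from compound 2 to compound 1 (within the scatter). In this assay the result of this change on one core therefore did not carry over to the other, and the two steps differ: the same change on two cores in this assay, no change at the digits printed (within the scatter) from compound 2 to compound 1 and a 2.9-fold lower number (0.46 log units; beyond the scatter) from compound 3 to compound 4, 2.9-fold (0.46 log units) apart, beyond the scatter of two such steps This is a single pair of steps for a single change; it does not show which feature of the two cores lies behind the gap, nor whether any other change at this place would carry over or fail to.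

Open, as far as these compounds go, is whether an unsubstituted phenyl or a methyl on the sulfonyl sulfur would separate the two cores as 3,4-dichlorophenyl does. Also open, from the compounds shown here alone, is which part of the difference between the cores matters, for instance whether the fluorine on the core of compound 4 has any part in the gap.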